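Dropping the amine side chain to a methyl group

The source may hold more compounds than are shown below. What is called first, only, known or untested is meant among the compounds shown, and "the series" means these compounds.

Measured compounds:
compound 1 `CCCCNc1nc(N)nc(C)c1CCCN1CCN(C)CC1` 179 nM
compound 2 `CCCCNc1nc(N)nc(C)c1CCCN(C)C` 126 nM

In an assay on HEK293 cells for agonist activity at Toll-like receptor 8 (Homo sapiens), read by spectrophotometry (a lower number here means that less compound is needed, a higher number that more compound is needed for the effect), compound 2 gives the lowest of the two numbers, yet a 1.4-fold lower number from compound 1 to compound 2 (0.15 log units; within the scatter). Compound 3 `CCCCNc1nc(N)nc(C)c1C` is not yet measured; it differs from compound 2 by hydrogen in place of 2-(dimethylamino)ethyl on a saturated chain carbon bound to an aromatic carbon. For the measured compounds named here, the single measured step only exchanged one amine for another and stayed within the scatter, so it says little about removing the whole chain. Compound 3 is therefore expected to need more compound, with a step of a 7.9-fold higher number from compound 2 to compound 3 (0.90 log units; beyond the scatter). The estimate for compound 3 is 1000 nM, in a range of 300 nM to 5000 nM.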

Compound 3, half-maximal effective concentration: 3280 nM
Compound 3: the middle estimate sits 3.3-fold (0.52 log units) below what was measured; the range from low to high includes it.
By their numbers in this assay, from the lowest: compounds 2 and 1 (each within the scatter of the next); then compound 3.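

In this assay, exchanging one amine for another between compound 1 and compound 2 stayed within the scatter, but cutting back the chain is a large change (a 26-fold higher number from compound 2 to compound 3 (1.42 log units; beyond the scatter)). What is attached at this saturated chain carbon therefore matters far more than which of these two amines ends the chain. Nothing available accounts for the size of this step. Still open, as far as these compounds go, is whether the amine nitrogen or the chain carbons carry the difference. A plain butyl chain, or a primary amine on the same chain, would separate the two.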